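Swapping the ester group on a shared core

The source may report more compounds than this note shows. Statements on the series, on what has been measured and on what is new or still open speak of the compounds shown alone.

Measured in an ADME assay on HepG2 2.2.15 cells (Homo sapiens) for cytotoxicity; on this read-out higher numbers stand for lower toxicity in this test and lower numbers for higher toxicity in this test:
Compound 1 `CCCCC(=O)OCCc1c(-c2ccccc2Cl)c2cc(Cl)ccc2[nH]c1=O`: 200000 nM
Compound 2 `O=C(OCCc1c(-c2ccccc2Cl)c2cc(Cl)ccc2[nH]c1=O)c1cccnc1`: 170000 nM

Compound 2, at 170000 nM, stands level with compound 1 on this read-out, as the two numbers lie within the scatter of each other. Among the measured compounds shown here, the one measured step, a 1.2-fold lower number from compound 1 to compound 2 (0.07 log units; within the scatter), puts pyridin-3-yl in place of butyl on a carbonyl carbon. Compound 3 `O=C(CN1C(=O)c2ccccc2C1=O)OCCc1c(-c2ccccc2Cl)c2cc(Cl)ccc2[nH]c1=O` keeps the shared core and changes that same place again: a group of 12 heavy atoms (9 carbon, 1 nitrogen, 2 oxygen; one five-membered non-aromatic ring with 1 hetero atom, one six-membered aromatic ring of carbon only) in place of a group of 6 heavy atoms (5 carbon, 1 nitrogen; one six-membered aromatic ring with 1 hetero atom), on a carbonyl carbon. The new group is bigger than either group measured so far, and neither compound 1 nor compound 2 carries its five-membered non-aromatic ring, so the support for any forecast is thin. Still, because of a 1.2-fold lower number from compound 1 to compound 2 (0.07 log units; within the scatter) no shift beyond the scatter is expected in this assay, and there is no measured basis for expecting a direction. The expected step is small, a 1.1-fold lower number from compound 2 to compound 3 (0.05 log units; within the scatter). For compound 3 the estimated value is 150000 nM, with an expected range from 70000 nM to 300000 nM.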

Compound 3, half-maximal cytotoxic concentration: 960000 nM
Beside the measured number, compound 3's estimate is 6.4-fold (0.81 log units) below it, outside the stated range (above it).
By their numbers in this assay, from the lowest: compounds 2 and 1 (each within the scatter of the next); then compound 3.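

On a carbonyl carbon of the ester, the read-out in this assay does respond to the group placed there: the group with a five-membered non-aromatic ring and a six-membered aromatic ring of carbon only gives a 5.6-fold higher number from compound 2 to compound 3 (0.75 log units; beyond the scatter) and also a 4.8-fold higher number from compound 1 to compound 3 (0.68 log units; beyond the scatter). Butyl and pyridin-3-yl had stood within the scatter of each other, so only this third group shows that the position can carry a modest difference, and its direction is towards a higher number, which on this read-out stands for lower toxicity in this test. Nothing in hand explains the shift or links it to any feature of the entering group.

As far as these compounds go, with three compounds, it stays open whether the shift belongs to the five-membered non-aromatic ring, to the two double bonds outside aromatic rings that enter with it, or simply to the larger count of heavy atoms. From the compounds shown here alone, it is equally open how a plain phenyl, a longer chain of similar heavy-atom count, or a group ending in an amine or a carboxylic acid would read at this same place on the shared core.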